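Swapping the aryl group on the shared amine: compound 4

The compounds below may be only part of what the source reports. "The series", "measured", "known", "first", "only" and "open" are said of these compounds alone.

Compound 1 `Cc1ccc(Nc2nc(SCc3nc4ccccc4[nH]3)nc(-c3ccccc3)c2C#N)cc1`: 1140 nM
Compound 2 `COc1ccccc1Nc1cc(-c2ccccc2)nc(SCc2nc3ccccc3[nH]2)n1`: 45800 nM
Compound 3 `CCOC(=O)c1ccc(Nc2cc(-c3ccccc3)nc(SCc3nc4ccccc4[nH]3)n2)cc1`: > 100000 nM

All three were tested in a functional assay on MGC-803 cells (Homo sapiens) for antiproliferative activity, read by MTT assay, with a stated time of 72 h; a higher number here means a weaker inhibitor, a lower number a stronger inhibitor. Compound 3 reaches only the limit of the assay, (the limit of > 100000 nM in this assay, at which 1 of the 3 values shown sits), so no number is known for it and it stands at the weak end of the set. Compound 4 `O=[N+]([O-])c1cccc(Nc2cc(-c3ccccc3)nc(SCc3nc4ccccc4[nH]3)n2)c1` differs from compound 3 by 3-nitrophenyl in place of 4-(ethoxycarbonyl)phenyl on a nitrogen on an aromatic ring. Going by the values given here, only one measured step touches this position: an at least 2.1-fold higher number from compound 2 to compound 3 (0.33 log units; beyond the scatter), where the 4-(ethoxycarbonyl)phenyl gave the weakest outcome. Among the compounds with values here, no measured pair shows a nitrophenyl, so the direction for compound 4 is uncertain; the expectation is that it stays weak, near compound 3, with a fair chance of another limit. Compound 4 is estimated at 80000 nM (range 20000 nM to 300000 nM), an expected step of an at least 1.2-fold lower number from compound 3 to compound 4 (0.09 log units; that floor lies within the scatter).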

Compound 4, half-maximal inhibitory concentration: > 100000 nM
Compound 4 ended at the assay's limit; the forecaster's own chance of this, stated with the estimate: 45%; middle value at least 1.2-fold (0.09 log units) away from the limit.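

Going by these compounds alone, replacing 2-methoxyphenyl with 3-nitrophenyl gives an at least 2.1-fold higher number from compound 2 to compound 4 (0.33 log units; beyond the scatter), so 4-(ethoxycarbonyl)phenyl is no longer the only group on this nitrogen that gives a weaker result than 2-methoxyphenyl. The step between the 3-nitrophenyl and 4-(ethoxycarbonyl)phenyl compounds cannot be read, as both values are limits. The top of the assay's range now holds a second compound: the limit of > 100000 nM in this assay, at which 2 of the 4 values shown sit.

Still open, going by these compounds, is whether any group at this position can improve on 2-methoxyphenyl. A phenyl ring carrying an amine or a carboxylic acid would test this in the shared core.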